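The source may hold more compounds than are shown below. What is called first, only, known or untested is meant among the compounds shown, and "the series" means these compounds.

Measured in a functional assay on MCF7 cells (Homo sapiens) for inhibition, read by MTT assay, with a stated time of 72 h, tested at 10 uM; on this read-out lower numbers stand for less inhibition and higher numbers for more inhibition at the one concentration tested (going by the name of the read-out):
compound 1, `CCOC(=O)C1=C(Nc2ccccc2)S/C(=C\c2ccc(O)c(O)c2)C1=O`, 38.1%;
compound 2, `CCOC(=O)C1=C(Nc2ccc(OC)cc2)S/C(=C\c2ccc[nH]2)C1=O`, < 10%.

Compound 1 gives a clear number in this assay. For compound 2 the read-out is not a number but (the limit of < 10% in this assay, at which 1 of the 2 values shown sits). Compound 3, `CCOC(=O)C1=C(Nc2ccc(C)cc2)S/C(=C\c2ccc[nH]2)C1=O`, differs from compound 2 by methyl in place of methoxy on an aromatic carbon. Among the measured compounds shown here, no measured pair shows what this change does, so the step of a number no lower from compound 2 to compound 3 (the limit leaves the size open) is expected to be small, within the usual scatter, and compound 3 may again return only a limit. Compound 3 is expected to give 10%, with a range from 3% to 25%.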

Compound 3, a percentage reported as inhibition, at one concentration (the size of the read-out at that concentration, not a potency): < 10%
Compound 3: no number, only a limit; the forecaster's own chance of this, stated with the estimate: 60%; the middle value sits exactly at the limit.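

No step can be read from compound 2 to compound 3, since each returns only a limit in this assay: the limit of < 10% in this assay, at which 2 of the 3 values shown sit.

The compounds shown leave open whether methyl in place of methoxy on an aromatic carbon alters inhibition at all.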